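A few compounds are considered here, and "the series" means these few. Any claim that something is new, unique, unknown or untested is made for them only; others in the source may bear on it.

Measured in a functional assay on MCF7 cells (Homo sapiens) for antiproliferative activity, read by WST assay, with a stated time of 72 h; a lower number here means a stronger inhibitor, a higher number a weaker inhibitor:

compound 1, `Cc1noc(-c2cc3cc(F)ccc3[nH]2)n1`, gives 12400 nM.
compound 2, `Cc1noc(-c2cc3cc(Cl)ccc3[nH]2)n1`, gives 34400 nM.
compound 3, `COc1ccc(-c2noc(-c3cc4cc(F)ccc4[nH]3)n2)cc1`, gives only a limit of the assay, > 50000 nM.

Compounds 1 and 2 share one core and differ in a single place: chloro in place of fluoro on an aromatic carbon. That change gave a 2.8-fold higher number from compound 1 to compound 2 (0.44 log units; beyond the scatter). Compound 3 carries another core; the difference between the two cores is not broken down here. Compound 3 sits at the limit (the limit of > 50000 nM in this assay, at which 1 of the 3 values shown sits). Compound 4, `COc1ccc(-c2noc(-c3cc4cc(Cl)ccc4[nH]3)n2)cc1`, has not yet been measured and differs from compound 3 by the same change at the same place: chloro in place of fluoro on an aromatic carbon. The same change gave a 2.8-fold higher number from compound 1 to compound 2 (0.44 log units; beyond the scatter), so compound 4 is expected to be weaker still, an estimated step that the limit leaves unreadable from compound 3 to compound 4. Compound 4 is therefore expected to give 100000 nM, most likely reported again only as a limit, somewhere between 50000 nM and 400000 nM.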

Compound 4, half-maximal inhibitory concentration: > 50000 nM
Compound 4 gave a limit, no number; the forecaster's own chance of this, stated with the estimate: 90%; the middle value is on the limit's open side.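

Compound 3 and compound 4 both give only a limit, so no step can be read between them: the limit of > 50000 nM in this assay, at which 2 of the 4 values shown sit.
The compounds shown leave open whether chloro in place of fluoro changes potency on the core of compound 3 as it did on the core of compound 1.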